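From vinyl to phenethyl on the shared sulfonate core

The source may report more compounds than this note shows. Statements on the series, on what has been measured and on what is new or still open speak of the compounds shown alone.

Compound 3 `C=CCOC1=CS(=O)(=O)OC1(CC)Cc1ccccc1` stands at the assay limit in an ADME assay on HEL cells (Homo sapiens) for cytotoxicity, with a stated time of 3 days (on this read-out higher numbers stand for lower toxicity in this test and lower numbers for higher toxicity in this test), giving only > 200000 nM. Compound 1 `CCC1(Cc2ccccc2)OS(=O)(=O)C=C1OCc1ccc(OC)cc1` likewise gives only the limit > 200000 nM. Compound 2 `CCC1(Cc2ccccc2)OS(=O)(=O)C=C1OCc1cccc(Cl)c1` gives 50000 nM in this assay. The step of an at least 4.0-fold lower number from compound 1 to compound 2 (0.60 log units; beyond the scatter) and the step of an at least 4.0-fold higher number from compound 2 to compound 3 (0.60 log units; beyond the scatter) show that a compound carrying an aromatic ring on this chain can reach a lower number, although compound 1 carries such a ring and stays at the limit; the step that the two limits leave unreadable from compound 1 to compound 3 cannot be read. Compound 4 `CCC1(Cc2ccccc2)OS(=O)(=O)C=C1OCCCc1ccccc1` differs from compound 3 by phenethyl in place of vinyl on a saturated chain carbon bound to an oxygen on an unsaturated carbon. In this assay the expected step of an at least 1.3-fold lower number from compound 3 to compound 4 (0.12 log units; that floor lies within the scatter) is therefore at most modest and downward. Compound 4 is estimated at 150000 nM, with a range from 40000 nM to 200000 nM.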

Compound 4, half-maximal cytotoxic concentration: 133000 nM
For compound 4 the middle estimate is 1.1-fold (0.05 log units) above the measured one; measured number inside the range.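

In this assay, phenethyl at this place gives a readable number, with an at least 1.5-fold lower number from compound 3 to compound 4 (0.17 log units; that floor lies within the scatter) and an at least 1.5-fold lower number from compound 1 to compound 4 (0.17 log units; that floor lies within the scatter); both floors lie within the scatter, so neither step shows a real drop. Phenethyl in place of 3-chlorophenyl gives a 2.7-fold higher number from compound 2 to compound 4 (0.42 log units; beyond the scatter), so an aromatic ring on this chain does not by itself bring the number down to that of compound 2. The two steps from the vinyl and 4-methoxyphenyl compounds remain floors only: the limit of > 200000 nM in this assay, at which 2 of the 4 values shown sit.

The compounds shown leave open how far the number falls with a longer chain ending in phenyl. They also leave open how an amine or a carboxylic acid would read at this place.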